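Amide variation in a weakly binding nitro-sulfone series

The compounds below may be only part of what the source reports. "The series", "measured", "known", "first", "only" and "open" are said of these compounds alone.

Measured so far:
compound 1, `CS(=O)(=O)c1ccc(C(=O)N2CCC(C(=O)N3CCN(c4ccc(F)cc4)CC3)CC2)cc1[N+](=O)[O-]`, limit of the assay: > 60000 nM
compound 2, `CS(=O)(=O)c1ccc(C(=O)NCCC(=O)N2CCCCC2)cc1[N+](=O)[O-]`, limit of the assay: > 60000 nM
compound 3, `CS(=O)(=O)c1ccc(C(=O)NCC(=O)N2CCCCC2)cc1[N+](=O)[O-]`: 44000 nM

In an assay on isolated protein for inhibition of thyroid hormone receptor alpha (Homo sapiens), read by fluorescence polarization (a higher number here means a weaker inhibitor, a lower number a stronger inhibitor), compound 2 gives only a limit, > 60000 nM, and no number. Compound 1 likewise returns a limit, > 60000 nM. Among the compounds with values here, compound 3 is the one compound with a numeric reading, 44000 nM. Taken together, most of the series sits at the limit of > 60000 nM in this assay, at which 2 of the 3 values shown sit, so compound 2 stands at the weak end of what this assay can report, with no measured step between it and any other compound.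

Compound 4, `CC(C)N(C(=O)CCNC(=O)c1ccc(S(C)(=O)=O)c([N+](=O)[O-])c1)C(C)C`, differs from compound 2 in one place: diisopropylamino in place of piperidin-1-yl on a carbonyl carbon. The amide carrying the sulfonyl-nitro aryl and the three-carbon chain are kept; only the terminal amide nitrogen substituent changes. Within the data shown here, since no measured pair isolates this kind of change, there is nothing to scale the expectation against. The expectation is that the step from compound 2 to compound 4 stays within the scatter, a step that the limit leaves unreadable from compound 2 to compound 4, with the reading most likely again a limit rather than a number. Compound 4 is therefore estimated at 70000 nM, with a range from 30000 nM to 200000 nM.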

Compound 4, half-maximal inhibitory concentration: > 60000 nM
Compound 4: a limit, no number (the forecaster's own chance of this, stated with the estimate: 70%); the middle value is on the limit's open side.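

Compound 4 gives only a limit of the assay, > 60000 nM. With compound 2 also a limit, no step can be read between compound 2 and compound 4. The compounds shown leave open whether diisopropylamino and piperidin-1-yl on a carbonyl carbon differ at all in this assay, as most of the series sits at the limit: the limit of > 60000 nM in this assay, at which 3 of the 4 values shown sit.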